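A few compounds are considered here, and "the series" means these few. Any claim that something is new, unique, unknown or untested is made for them only; others in the source may bear on it.

Of the compounds shown here, three have been measured in an assay on MDA-MB-231 cells for binding affinity to C-X-C chemokine receptor type 4 (Homo sapiens), read by fluorescence and microscopy, with stated times of 10 min and 30 min; on this read-out lower numbers stand for an effect already at smaller amounts and higher numbers for an effect only at larger amounts of compound. Compound 1 `Cc1ccc(S(=O)(=O)NCc2ccc(CNC(=O)c3ccc(F)cn3)cc2)cc1` gives 1000 nM. Compound 2 `O=C(NCc1ccc(CNS(=O)(=O)c2ccc(CN3CCCC3)cc2)cc1)c1ccc(F)cc1` gives 1 nM. Compound 3 `O=C(NCc1ccc(CNS(=O)(=O)c2ccc(Cl)cc2)cc1)c1ccc(F)cc1` gives 100 nM. On these numbers compound 3 stands second highest of the three: the nearest is compound 1, and the furthest is compound 2. Among the measured compounds shown here, the one single-point step in the set is a 100-fold higher number from compound 2 to compound 3 (2.00 log units; beyond the scatter), a chloro in place of a (pyrrolidin-1-yl)methyl on an aromatic carbon.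

Compound 4 `O=C(NCc1ccc(CNS(=O)(=O)c2ccccc2Cl)cc1)c1ccc(F)cc1` has not yet been measured. It differs from compound 3 by 2-chlorophenyl in place of 4-chlorophenyl on a sulfonyl sulfur, so the same atoms are joined differently: 2-chlorophenyl in place of 4-chlorophenyl on a sulfonyl sulfur. For the measured compounds named here, no measured step moves a chlorine from one place on this ring to another; the step from compound 2 to compound 3 swaps a whole group at the same ring, which is a different kind of change, so it gives no direct guide. With nothing to point either way, compound 4 is expected to land near compound 3, with a step of a 1.5-fold higher number from compound 3 to compound 4 (0.18 log units; within the scatter) in this assay that would not exceed the scatter. The estimate for compound 4 is therefore 150 nM, with a range from 40 nM to 600 nM.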

Compound 4, effective concentration (reported as EC, without a stated level of effect): 1000 nM
Beside the measured number, compound 4's estimate is 6.7-fold (0.82 log units) below it; the whole stated range lies below it.
By their numbers in this assay, from the lowest: compound 2; then compound 3; then compounds 1 and 4 (each within the scatter of the next).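

In this assay, shifting only the chlorine on the ring gives a 10-fold higher number from compound 3 to compound 4 (1.00 log units; beyond the scatter), so the two compounds hold the same atoms and the way they are joined is enough to change the number beyond the scatter. The earlier step at this ring, a 100-fold higher number from compound 2 to compound 3 (2.00 log units; beyond the scatter), exchanged a whole group and could not show that the place of a single chlorine matters, with 2-chlorophenyl on the sulfonyl sulfur now giving the higher number and 4-chlorophenyl the lower. Nothing at hand measures what lies behind this difference, so the step stands as an observation without an explanation.

From the compounds shown here alone, whether 3-chlorophenyl on the sulfonyl sulfur would give a number closer to that of compound 3 or that of compound 4 stays open. Going by these compounds, it is also open whether 2-fluorophenyl or 2-methylphenyl there would give a step of the same size, which would help tell whether the step belongs to chlorine itself or to any small group placed as in 2-chlorophenyl.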